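This account rests on a few compounds, and the source may have more. Where it says the series, first, only, none or still open, it means among the compounds named here.

Compound 1 `COc1cc(/C=N/NC(=O)c2ccncc2)cc(OC)c1O`: in a physicochemical assay, read by spectrophotometry (on this read-out lower numbers stand for stronger inhibition and higher numbers for weaker inhibition), compound 1 gives 17000 nM.
Compound 2 `COc1cc(/C=N/NC(=O)c2ccncc2)cc(OC)c1OC`: in this assay compound 2 gives > 1000000 nM, which is a limit of the assay and not a number.

Within the data shown here, compound 1 therefore carries the only number that this assay has produced so far; the other value is the limit of > 1000000 nM in this assay, at which 1 of the 2 values shown sits. Among the measured compounds shown here, the one measured step that joins the two runs an at least 58-fold higher number from compound 1 to compound 2 (1.76 log units; beyond the scatter), with the methyl group entering on the oxygen of the ring.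

Compound 3 `COc1cc(/C=N/NC(=O)c2ccncc2)cc(O)c1O` differs from compound 1 by hydrogen in place of methyl on an oxygen on an aromatic ring. The step from compound 1 to compound 2 bears on it directly, since it is the same kind of exchange taken the other way. For the measured compounds named here, that step moved the number sharply upward, so the reverse exchange is expected to move it downward, although only one such step exists to lean on and its size is bounded by a limit. Compound 3 is therefore expected to reach 4000 nM, within 800 nM to 17000 nM, a step of a 4.3-fold lower number from compound 1 to compound 3 (0.63 log units; beyond the scatter).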

Compound 3, half-maximal inhibitory concentration: 18400 nM
The estimate for compound 3 lay 4.6-fold (0.66 log units) below the measured number, and the stated range ends below it.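

In this assay, the exchange of methoxy to hydroxy gives a 1.1-fold higher number from compound 1 to compound 3 (0.03 log units; within the scatter), so at this oxygen on the aromatic ring, methyl and hydrogen cannot be told apart. The earlier step, an at least 58-fold higher number from compound 1 to compound 2 (1.76 log units; beyond the scatter), was made at a different oxygen on the same ring, and this shows that the same kind of exchange does not give the same result at both oxygens of the shared core. The value of compound 2 remains a limit of the assay and not a number: the limit of > 1000000 nM in this assay, at which 1 of the 3 values shown sits.

The compounds shown leave open whether an ethyl group or a longer chain on this oxygen would leave the number as unchanged as hydrogen does. They also leave open what an amine in place of the methoxy group would do.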